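Ortho-substituted aryl ureas: halogen swap at the ortho position

A few compounds are considered here, and "the series" means these few. Any claim that something is new, unique, unknown or untested is made for them only; others in the source may bear on it.

Measured so far:
compound 1 `Cc1ccccc1NC(=O)N[C@H](C)c1ccccc1` — 100%
compound 2 `CC(C)c1ccccc1NC(=O)N[C@H](C)c1ccccc1` — 101%
compound 3 `C[C@@H](NC(=O)Nc1ccccc1Cl)c1ccccc1` — 103%

In an ADME assay on the whole organism with Oryza sativa as the target, tested at 1 uM (a higher number here means a weaker effect of the compound at the concentration tested, a lower number a stronger effect), compound 1 gives 100% and compound 2 gives 101%, a step of a number 1 percentage points higher from compound 1 to compound 2 (within the scatter). Compound 3 gives 103%, which is the highest of the three numbers, yet its steps from the others, a number 3 percentage points higher from compound 1 to compound 3 (within the scatter) and a number 2 percentage points higher from compound 2 to compound 3 (within the scatter), are both within the scatter. Across these three compounds the group on the aromatic carbon makes no difference that rises above the noise.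

Compound 4 `C[C@@H](NC(=O)Nc1ccccc1I)c1ccccc1` is not yet measured. It differs from compound 3 by iodo in place of chloro on an aromatic carbon. Going by the values given here, the steps that bear on this change are those exchanging one small group for another at the same aromatic carbon, a number 3 percentage points higher from compound 1 to compound 3 (within the scatter) and a number 2 percentage points higher from compound 2 to compound 3 (within the scatter), both within the scatter. A step of similar size is therefore expected in this assay, with no direction beyond the scatter, so a number 2 percentage points lower from compound 3 to compound 4 (within the scatter) is the estimated step. Compound 4 is expected to give 101%, in a range from 90% to 112%.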

Compound 4, a percentage reported as activity, at one concentration (the size of the read-out at that concentration, not a potency): 100%
Beside the measured number, compound 4's estimate is 1 percentage points above it, and the stated range covers the measured number.
By their numbers in this assay, from the lowest: compounds 1, 4, 2 and 3 (each within the scatter of the next).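

In this assay the swap to iodo at this aromatic carbon, ortho to a large group, brings a second halogen into the comparison, and the steps read a number 3 percentage points lower from compound 3 to compound 4 (within the scatter) and a number 1 percentage points lower from compound 2 to compound 4 (within the scatter) and no change at the digits printed from compound 1 to compound 4 (within the scatter). The earlier compounds covered methyl, isopropyl and chloro; iodo now joins them, and no step among these four groups rises above the scatter, so this position has so far shown no sensitivity to the exchange of one of these groups for another. No measurement at hand accounts for this flat result.

On these data alone, whether an amine, a carboxylic acid or a longer chain at this aromatic carbon would move the number beyond the scatter remains open. Also open, as far as these compounds go, is whether a change elsewhere on the shared core would do so.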